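Extending the side chain of compound 2 into an amide-linked aminoethyl group

A few compounds are considered here, and "the series" means these few. Any claim that something is new, unique, unknown or untested is made for them only; others in the source may bear on it.

Among the compounds with values here, compound 2, `CCN[C@H](c1cc(C(F)(F)F)ccc1N1CCN(C(=O)CCc2ccc(Cl)cc2Cl)CC1)C(C)CC`, gives 92 nM in an assay on HEK293 cells for displacement of a labelled ligand from Melanocortin receptor 4 (Homo sapiens) (a higher number here means a weaker inhibitor, a lower number a stronger inhibitor), the lower of two numbers so far; compound 1, `COc1cc(OC)c(OC)cc1CCC(=O)N1CCN(c2ccc(C(F)(F)F)cc2[C@@H](N)CC(C)C)CC1`, gives 6100 nM in this assay. Compound 3, `CC(C)C[C@H](NC(=O)CCN)c1cc(C(F)(F)F)ccc1N1CCN(C(=O)CCc2ccc(Cl)cc2Cl)CC1`, has not yet been measured. Its difference from compound 2 is 1-(((2-aminoethyl)carbonyl)amino)-3-methylbutyl in place of 1-(ethylamino)-2-methylbutyl on an aromatic carbon. Within the data shown here, with no comparable step among the measured pair, the expected change is uncertain; the estimated step of a 3.8-fold higher number from compound 2 to compound 3 (0.58 log units; beyond the scatter) points to a moderately higher number, beyond the scatter. Compound 3 is therefore expected to give about 350 nM, within a range of 60 nM to 2500 nM.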

Compound 3, inhibition constant: 25 nM
The estimate for compound 3 lay 14-fold (1.15 log units) above the measured number; the measured number lies below the stated range.
By their numbers in this assay, from the lowest: compound 3; then compound 2; then compound 1.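

In this assay, within the data shown here, 1-(((2-aminoethyl)carbonyl)amino)-3-methylbutyl in place of 1-(ethylamino)-2-methylbutyl on this aromatic carbon gives a 3.7-fold lower number from compound 2 to compound 3 (0.57 log units; beyond the scatter) and is the first step that can be read at this position. The position therefore tolerates the larger amide-linked group, which ends in an amine, with no rise in the number. Nothing available explains the fall in the number. The change alters the nitrogen substituent and the alkyl branching together, and the compounds shown do not separate the two. On these data alone, whether a longer chain or a carboxylic acid in place of the amine would hold this number remains open.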